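The compounds below may be only part of what the source reports. "The series", "measured", "known", "first", "only" and "open" are said of these compounds alone.

Compound 1 `NS(=O)(=O)NCC1CCN(c2cc(-c3ccc(Cl)cc3)ncn2)CC1` gives 37700 nM in a functional assay on HT-29 cells (Homo sapiens) for antiproliferative activity, read by sulforhodamine B assay, with a stated time of 48 h; a higher number here means a weaker inhibitor of growth, a lower number a stronger inhibitor of growth. Going by the values given here, compound 2 `CCOC(=O)c1ccc(-c2cc(N3CCC(CNS(N)(=O)=O)CC3)ncn2)cc1` gives 5700 nM in this assay, the lower of the two numbers measured so far, and the only measured step, a 6.6-fold lower number from compound 1 to compound 2 (0.82 log units; beyond the scatter), concerns the aromatic end of the shared core. Compound 3 `CCOC(=O)c1ccc(-c2cc(N3CCC(CCNS(N)(=O)=O)CC3)ncn2)cc1` differs from compound 2 at the chain end instead: (sulfamoylamino)methyl in place of sulfamoylamino on a saturated chain carbon bound to a saturated ring carbon. Among the compounds with values here, no measured step bears on this chain; the single step in hand, a 6.6-fold lower number from compound 1 to compound 2 (0.82 log units; beyond the scatter), alters a different place and carries no information on lengthening the chain, so the expectation for compound 3 in this assay is no change beyond the scatter, with the range kept wide for want of a precedent. For compound 3 the expected step of no change at the digits printed from compound 2 to compound 3 (within the scatter) is accordingly small. Compound 3 is estimated at 5700 nM in this assay, with a range from 1800 nM to 18000 nM.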

Compound 3, concentration for 50% growth inhibition: 6800 nM
For compound 3 the middle estimate is 1.2-fold (0.08 log units) below the measured one; the measured number falls inside the stated range.
By their numbers in this assay, from the lowest: compounds 2 and 3 (each within the scatter of the next); then compound 1.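

In this assay, the chain now has a measured step of its own: a 1.2-fold higher number from compound 2 to compound 3 (0.08 log units; within the scatter). At this place, on a saturated chain carbon bound to a saturated ring carbon, compound 2 and compound 3 cannot be told apart, so the (sulfamoylamino)methyl and 2-(sulfamoylamino)ethyl forms read alike here, although this rests on a single pair carrying ethoxycarbonyl. No evidence bearing on the origin of this result is available.

Still open, as far as these compounds go, is whether a longer chain such as 3-(sulfamoylamino)propyl, or an amine in place of the sulfamoylamino group, would stay within the scatter of compound 3. Also open, from the compounds shown here alone, is whether the chain result holds with chloro on the aromatic carbon, the group carried by compound 1.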